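This account rests on a few compounds, and the source may have more. Where it says the series, first, only, none or still open, it means among the compounds named here.

Compound 1 `Cc1nc(-c2ccc(F)cc2)c(C(=O)N2CCN(c3cc(Cl)cc(Cl)c3)CC2)o1` gives 71.8% in an ADME assay (liver) for metabolic stability, with Liver microsome (Homo sapiens) as the target, read by LC-MS, using microsomes, with a stated time of 1 h, tested at 5 uM; a higher number here means that more of the compound is left, a lower number that less of the compound is left.
Compound 2 `COc1cc(OC)cc(N2CCN(C(=O)c3oc(C)nc3-c3ccc(F)cc3)CC2)c1` gives 12.9%.
Compound 3 `Cc1nc(-c2cccc(F)c2)c(C(=O)N2CCN(c3cc(Cl)cc(Cl)c3)CC2)o1` gives 75.9%.

Compound 4 `COc1cc(OC)cc(N2CCN(C(=O)c3oc(C)nc3-c3cccc(F)c3)CC2)c1` has not been measured. The cores of compound 1 and compound 3 differ by 3-fluorophenyl in place of 4-fluorophenyl on an aromatic carbon, a change that gave a number 4.1 percentage points higher from compound 1 to compound 3 (within the scatter). The change from compound 1 to compound 2 is 3,5-dimethoxyphenyl in place of 3,5-dichlorophenyl on an amine nitrogen in a ring and gave a number 58.9 percentage points lower from compound 1 to compound 2 (beyond the scatter). The same change, (3,5-dimethoxyphenyl in place of 3,5-dichlorophenyl on an amine nitrogen in a ring), occurs twice among these compounds, the second time leading to compound 4, at a place described in identical words. A step of like size is expected in this assay: a number 58.9 percentage points lower from compound 3 to compound 4 (beyond the scatter). This expectation rests on compound 3 giving 75.9% and on the earlier a number 58.9 percentage points lower from compound 1 to compound 2 (beyond the scatter). Compound 4 is therefore expected to give 17%, estimated between 7% and 32%.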

Compound 4, percent of the compound remaining: 11.3%
Compound 4: middle estimate off by 5.7 percentage points, on the high side, and the stated range covers the measured number.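

In this assay, 3,5-dimethoxyphenyl in place of 3,5-dichlorophenyl on an amine nitrogen in a ring carries over to the second core, with a number 64.6 percentage points lower from compound 3 to compound 4 (beyond the scatter), a step of like size to the earlier one: the same change on two cores in this assay, a number 58.9 percentage points lower (beyond the scatter) from compound 1 to compound 2 and a number 64.6 percentage points lower (beyond the scatter) from compound 3 to compound 4, 5.7 percentage points apart, within the scatter of two such steps. The exchange of 4-fluorophenyl for 3-fluorophenyl also carries over, with a number 1.6 percentage points lower from compound 2 to compound 4 (within the scatter), and remains within the scatter on both backgrounds: the same change on two cores in this assay, a number 4.1 percentage points higher (within the scatter) from compound 1 to compound 3 and a number 1.6 percentage points lower (within the scatter) from compound 2 to compound 4, 5.7 percentage points apart, within the scatter of two such steps. This shows that the two changes combine consistently across these four compounds, but not that the large step would persist on cores differing by more than this fluorophenyl exchange.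

The compounds shown leave open how a phenyl bearing a single methoxy group or a 3,5-difluorophenyl would read at the same place. Also open, on these data alone, is whether the step would hold with a longer chain or an amine elsewhere on the shared core.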